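Cyclopentylamino for octyloxy on the shared core: cytotoxicity

A few compounds are considered here, and "the series" means these few. Any claim that something is new, unique, unknown or untested is made for them only; others in the source may bear on it.

Compound 1 `CCCCCCCCOc1nc(N)nc2c1ncn2/C=C1/CC1(CO)CO` gives > 20000 nM in an ADME assay on Akata cells (Homo sapiens) for cytotoxicity, with a stated time of 7 days (a lower number here means that less compound is tolerated, a higher number that more compound is tolerated), a limit of the assay and not a number.
Compound 2 `Nc1nc(OCc2ccccc2)c2ncn(/C=C3/CC3(CO)CO)c2n1` gives > 20000 nM in this assay, again only a limit.
Compound 3 `Nc1nc(NCc2ccccc2)c2ncn(/C=C3/CC3(CO)CO)c2n1` gives > 24000 nM in this assay, also a limit.

Among the compounds with values here, compound 1 thus stands only at a limit, and the two further values are limits as well, so no compound in the set can be ranked against another. Two of the three values sit at the limit of > 20000 nM in this assay, at which 2 of the 3 values shown sit, and one at the limit of > 24000 nM in this assay, at which 1 of the 3 values shown sits.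

Compound 4 `Nc1nc(NC2CCCC2)c2ncn(/C=C3/CC3(CO)CO)c2n1` differs from compound 1 by cyclopentylamino in place of octyloxy on an aromatic carbon. Three measured steps at the same place on the core bear on this: a step that the two limits leave unreadable from compound 1 to compound 2, a step that the two limits leave unreadable from compound 1 to compound 3 and a step that the two limits leave unreadable from compound 2 to compound 3. None is readable; each shows only that phenyl for heptyl, benzylamino for octyloxy and benzylamino for benzyloxy all left the read-out at a limit. The present change, like the step to compound 3, puts an amino-linked group in place of the octyloxy, and nothing in the set points to a step beyond the scatter in either direction.

Compound 4 is therefore expected to give 25000 nM, within a range from 12000 nM to 60000 nM, most probably again as a limit. The step expected from this is a step that the limit leaves unreadable from compound 1 to compound 4, that is, none beyond the scatter.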

Compound 4, half-maximal cytotoxic concentration: > 20000 nM
Compound 4: no number, only a limit (the forecaster's own chance of this, stated with the estimate: 85%); the middle value is on the limit's open side.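

In this assay compound 4 gives > 20000 nM, a limit and not a number, so its steps from compound 1, compound 2 and compound 3 cannot be read. The compounds shown leave open where any true half-maximal cytotoxic concentration lies and whether these groups differ at all.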